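Swapping cyclobutyl for a methyl-oxazolylmethyl group on the ether oxygen

A few compounds are considered here, and "the series" means these few. Any claim that something is new, unique, unknown or untested is made for them only; others in the source may bear on it.

Measured so far in an ADME assay (liver) for pharmacokinetics, with Liver microsome (Rattus norvegicus) as the target, read by LC-MS, using microsomes, tested at 2 uM; a higher number here means faster removal of the compound, a lower number slower removal:
- compound 1 `O=C(N[C@@H]1CCCC[C@H]1O)c1cnc(Oc2ccccc2)c(-c2ccc(Cl)cc2)c1`: 0.353 mL/min/kg
- compound 2 `O=C(N[C@@H]1CCCC[C@H]1O)c1cnc(OC2CCC2)c(-c2ccc(Cl)cc2)c1`: 0.21 mL/min/kg
- compound 3 `O=C(N[C@@H]1CCCC[C@H]1O)c1cnc(OCc2ccccc2)c(-c2ccc(Cl)cc2)c1`: 0.02 mL/min/kg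

Compound 2, at 0.21 mL/min/kg, lies within the scatter of compound 1, and its number is clearly higher than that of compound 3. The next structure is compound 4 `Cc1cc(COc2ncc(C(=O)N[C@@H]3CCCC[C@H]3O)cc2-c2ccc(Cl)cc2)on1`, and the change is (3-methyl-1,2-oxazol-5-yl)methyl in place of cyclobutyl on an oxygen on an aromatic ring.

Going by the values given here, three measured steps bear on this change. Replacing phenyl with cyclobutyl gave a 1.7-fold lower number from compound 1 to compound 2 (0.23 log units; within the scatter). Benzyl gave two large steps, an 11-fold lower number from compound 2 to compound 3 (1.02 log units; beyond the scatter) and an 18-fold lower number from compound 1 to compound 3 (1.25 log units; beyond the scatter). Benzyl is the closest measured group to the one entering here, since both carry an aromatic ring on a single carbon attached to the oxygen. However, no measured compound has a five-membered aromatic ring at this place, so only part of the benzyl step is expected to carry over.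

In this assay a lower number is therefore expected, with an estimated step of a 3.5-fold lower number from compound 2 to compound 4 (0.54 log units; beyond the scatter). The estimated value for compound 4 is 0.06 mL/min/kg, with an expected range of 0.015 mL/min/kg to 0.3 mL/min/kg.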

Compound 4, clearance: 0.151 mL/min/kg
Compound 4: the middle estimate sits 2.5-fold (0.40 log units) below what was measured; measured number inside the range.
By their numbers in this assay, from the lowest: compound 3; then compounds 4, 2 and 1 (each within the scatter of the next, the first and the last beyond it).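

In this assay, (3-methyl-1,2-oxazol-5-yl)methyl in place of cyclobutyl on the ether oxygen gave a 1.4-fold lower number from compound 2 to compound 4 (0.14 log units; within the scatter), so this change does not separate the two compounds. An aromatic ring on a single carbon at this oxygen is thus not enough to reach the low number of the benzyl compound: 3-methyl-1,2-oxazol-5-yl in place of phenyl on that carbon gave a 7.6-fold higher number from compound 3 to compound 4 (0.88 log units; beyond the scatter). The same group in place of phenyl on the oxygen gave a 2.3-fold lower number from compound 1 to compound 4 (0.37 log units; beyond the scatter), a step beyond the scatter, whereas the step from phenyl to cyclobutyl stayed within it.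

No measurement given here accounts for these differences. The compounds shown leave open whether the gap to benzyl follows the five-membered ring, its hetero atoms or its methyl, and where a pyridinylmethyl group or a longer chain such as phenylethyl would fall at this oxygen.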